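From 2-hydroxyhexyl to 2-hydroxy-2-methylhexyl: compound 3

This account rests on a few compounds, and the source may have more. Where it says the series, first, only, none or still open, it means among the compounds named here.

- compound 1 `CCCCC(O)C/C=C/[C@H]1[C@H](O)CC(=O)[C@@H]1CCCCCCC(=O)OC`: 0.0054 mg/kg
- compound 2 `CCCCC(O)C/C=C/[C@H]1[C@H](O)CC(=O)[C@@H]1C/C=C\CCCC(=O)OC`: 0.0041 mg/kg

Both compounds were tested in a functional assay on the whole organism (strain Mongrel) for inhibition, with Canis familiaris (Canis lupus familiaris) as the target; on this read-out lower numbers stand for an effect already at smaller amounts and higher numbers for an effect only at larger amounts of compound. Compound 2 gives 0.0041 mg/kg and compound 1 gives 0.0054 mg/kg. These two values lie within the scatter of each other, so compound 2 stands level with compound 1 on the numbers available.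

Compound 3 `CCCCC(C)(O)C/C=C/[C@H]1[C@H](O)CC(=O)[C@@H]1C/C=C\CCCC(=O)OC` is the next compound to be examined in this assay. The change from compound 2 is methyl in place of hydrogen on a saturated chain carbon bound to an oxygen on a saturated carbon and two saturated chain carbons. This turns 2-hydroxyhexyl into 2-hydroxy-2-methylhexyl.

Among the compounds with values here, the measured compounds include no example of this change, so the expectation carries real uncertainty. A small move towards a lower number is expected, but nothing beyond the scatter. The expected change is a 1.4-fold lower number from compound 2 to compound 3 (0.14 log units; within the scatter). For compound 3 the estimated value is 0.003 mg/kg, with an expected range from 0.001 mg/kg to 0.01 mg/kg.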

Compound 3, dose for 50% inhibition: 0.0003 mg/kg
Compound 3: the middle estimate sits 10-fold (1.00 log units) above what was measured, and the stated range ends above it.
By their numbers in this assay, from the lowest: compound 3; then compounds 2 and 1 (each within the scatter of the next).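

In this assay, methyl in place of hydrogen on a saturated chain carbon bound to an oxygen on a saturated carbon and two saturated chain carbons, which turns 2-hydroxyhexyl into 2-hydroxy-2-methylhexyl, gives a 14-fold lower number from compound 2 to compound 3 (1.14 log units; beyond the scatter). Compound 1 and compound 2 both carry the 2-hydroxyhexyl group and differ only in the other chain, where their values lie within the scatter of each other, so this position is the first place among the compounds shown where one change moves the number clearly beyond the scatter. Nothing available gives a measured reason for the size of this step.

On these data alone, it remains open whether the step depends on the methyl group itself, since ethyl, a longer chain or a second methyl on a neighbouring chain carbon at this end of the molecule could give a different number. As far as these compounds go, it is equally open whether the same change carries over to the saturated chain of compound 1, and whether a methyl ether in place of the hydroxyl would keep any of the effect.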